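Macrocyclic esters: growth inhibition across a side-chain change

A few compounds are considered here, and "the series" means these few. Any claim that something is new, unique, unknown or untested is made for them only; others in the source may bear on it.

Measured so far:
Compound 1, `O=C(/C=C/c1ccccc1)OCC1COCCOCCOCCOCCOCCO1`, gives 57000 nM in a functional assay on HBL-100 cells (Homo sapiens) for inhibition, read by sulforhodamine B assay, with a stated time of 48 h; a lower number here means a stronger inhibitor of growth, a higher number a weaker inhibitor of growth.
Compound 2, `CC/C=C/CC(=O)OCC1COCCOCCOCCOCCOCCO1`, reaches the limit > 100000 nM in this assay.

Compound 2 thus stands at a limit, not at a number, and the step of an at least 1.7-fold higher number from compound 1 to compound 2 (0.24 log units; that floor lies within the scatter) is bounded on one side only; the limit of > 100000 nM in this assay, at which 1 of the 2 values shown sits, marks that edge. Compound 3, `O=C(CCCCOc1ccccc1)OCC1COCCOCCOCCOCCOCCO1`, differs from compound 2 by 3-phenoxypropyl in place of but-1-en-1-yl on a saturated chain carbon bound to a carbonyl carbon. Going by the values given here, the single measured step, from compound 1 to compound 2, replaced 2-phenylethenyl with pent-2-en-1-yl and ended at the limit; the present step brings a six-membered aromatic ring back through a saturated tether. Among the compounds with values here, no measured step mirrors this change, so its size can only be guessed. Compound 3 is expected to land near where compound 1 sits, so an at least 1.4-fold lower number from compound 2 to compound 3 (0.15 log units; that floor lies within the scatter) is expected as a move back from the limit, possibly within the scatter. Compound 3 is estimated at 70000 nM, between 25000 nM and 200000 nM.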

Compound 3, concentration for 50% growth inhibition: > 100000 nM
Compound 3: no number, only a limit; the forecaster's own chance of this, stated with the estimate: 40%; middle value at least 1.4-fold (0.15 log units) from the limit.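

In this assay compound 3 gives only a limit, > 100000 nM, and not a number. A six-membered aromatic ring carried on 3-phenoxypropyl thus yields no readable value at this position, so an aromatic ring in the side chain does not by itself secure one; set against 2-phenylethenyl, 4-phenoxybutyl gives an at least 1.7-fold higher number from compound 1 to compound 3 (0.24 log units; that floor lies within the scatter), which is a floor only and leaves open how far the true value lies from the earlier number. The step between compound 2 and compound 3 cannot be read, and the series now gathers at one edge: the limit of > 100000 nM in this assay, at which 2 of the 3 values shown sit.

As far as these compounds go, how far compound 2 and compound 3 lie past the limit remains open. Also open, from the compounds shown here alone, is whether a shorter chain to the phenoxy group, or an amine or a carboxylic acid on the aromatic ring of 2-phenylethenyl, would give a readable value.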